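Aryl change on the weakly cytotoxic series

This account rests on a few compounds, and the source may have more. Where it says the series, first, only, none or still open, it means among the compounds named here.

- compound 1 `COc1ccc(-n2ccc(=O)c(C(=O)Nc3ccc(Oc4ccnc5c4ccn5C)cc3)n2)cc1`: > 60000 nM (a limit)
- compound 2 `Cn1ccc2c(Oc3ccc(NC(=O)c4nn(-c5ccc(Br)cc5)ccc4=O)cc3)ccnc21`: 39200 nM

Among the compounds with values here, in a functional assay on HepG2 cells (Homo sapiens) for cytotoxicity, read by MTT assay, with a stated time of 72 h (on this read-out lower numbers stand for stronger inhibition and higher numbers for weaker inhibition), compound 2 gives 39200 nM, the only actual number so far. For compound 1 the entry > 60000 nM is a limit, not a number. Compound 3 `Cn1ccc2c(Oc3ccc(NC(=O)c4nn(-c5ccc(Cl)c(C(F)(F)F)c5)ccc4=O)cc3)ccnc21` differs from compound 2 as follows: 4-chloro-3-(trifluoromethyl)phenyl in place of 4-bromophenyl on an aromatic nitrogen. Within the data shown here, the one measured step, an at least 1.5-fold lower number from compound 1 to compound 2 (0.18 log units; that floor lies within the scatter), also changes a substituent on this aromatic ring, and it rests on (the limit of > 60000 nM in this assay, at which 1 of the 2 values shown sits). On that thin basis, only a small drop is expected in this assay. The expected step is a 1.6-fold lower number from compound 2 to compound 3 (0.20 log units; within the scatter). For compound 3 the estimate is 25000 nM, with a range of 9000 nM to 60000 nM.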

Compound 3, half-maximal inhibitory concentration: 23400 nM
Compound 3: the middle estimate sits 1.1-fold (0.03 log units) above what was measured; the measured number falls inside the stated range.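

In this assay, 4-chloro-3-(trifluoromethyl)phenyl in place of 4-bromophenyl on the aromatic nitrogen gives a 1.7-fold lower number from compound 2 to compound 3 (0.22 log units; within the scatter), so the added heavy atoms bring no clear separation at this position. Within the data shown here, replacing 4-methoxyphenyl with the same group gives an at least 2.5-fold lower number from compound 1 to compound 3 (0.40 log units; beyond the scatter), the first step at this position beyond the scatter. That size is only a floor, since compound 1 carries a limit: the limit of > 60000 nM in this assay, at which 1 of the 3 values shown sits.

As far as these compounds go, the separate contributions of the chloro and trifluoromethyl groups remain open. So does the effect of an amine or a carboxylic acid on this aryl ring.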